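The source may hold more compounds than are shown below. What is called first, only, known or untested is meant among the compounds shown, and "the series" means these compounds.

Of the compounds shown here, two have so far been measured in a toxicity assay on A549 cells (Homo sapiens) for cytotoxicity, read by luminescence and CellTiter-Glo, with a stated time of 48 h; on this read-out higher numbers stand for lower toxicity in this test and lower numbers for higher toxicity in this test. Compound 1, `CCCCOc1ccc(-c2nc3ncccn3c2NCc2ccc(OC)cc2)cc1`, gives 55000 nM in this assay. Compound 2, `COCCCCOc1ccc(-c2nc3ncccn3c2NC2CCCCC2)cc1`, gives 100000 nM in this assay, the highest of the two numbers shown, and its nearest neighbour is compound 1, whose number lies within the usual scatter of that of compound 2, so the two cannot be told apart on these data. Compound 3, `c1ccc(-c2nc3ncccn3c2NC2CCCCC2)cc1`, has not yet been measured. It differs from compound 2 in one place: hydrogen in place of 4-methoxybutoxy on an aromatic carbon. Within the data shown here, no pair of measured compounds shows this change, so nothing measured here tells how large a step it brings. Both measured compounds carry a longer group at that place and sit close together in this assay. For compound 3 only a small step is therefore expected, one that need not exceed the scatter, and the expected step is a 1.3-fold lower number from compound 2 to compound 3 (0.12 log units; within the scatter). Compound 3 is expected to give about 75000 nM in this assay, with a range from 30000 nM to 150000 nM.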

Compound 3, half-maximal cytotoxic concentration: 100000 nM
For compound 3 the middle estimate is 1.3-fold (0.12 log units) below the measured one; the range from low to high includes it.
By their numbers in this assay, from the lowest: compounds 1, 2 and 3 (each within the scatter of the next).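

In this assay, replacing the 4-methoxybutoxy group with hydrogen brings no change at the digits printed from compound 2 to compound 3 (within the scatter). Among these compounds, this pair is the first to isolate a change at this place, on an aromatic carbon of a six-membered aromatic ring of carbon only, para to a large group, and it shows that the whole 4-methoxybutoxy chain can leave without the read-out moving beyond the scatter. Nothing available offers an explanation for this result.

From the compounds shown here alone, the comparison covers only hydrogen and this one chain at this place, so it remains open whether an amine, a carboxylic acid or a shorter alkoxy chain there would leave the number equally unmoved. Going by these compounds, it also remains open whether the same replacement would have so little consequence in the setting of compound 1, which carries a butoxy chain at this place and a different group elsewhere on the shared core.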